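The source may report more compounds than this note shows. Statements on the series, on what has been measured and on what is new or still open speak of the compounds shown alone.

Measured so far:
- compound 1 `Nc1nc(Nc2ccccc2)nc2[nH]c(=O)c(-c3c(F)cccc3F)cc12` — 2400 nM
- compound 2 `Nc1nc(Nc2ccccc2)nc2[nH]c(=O)c(-c3ccccc3)cc12` — 13800 nM
- compound 3 `Cn1c(=O)c(-c2ccccc2)cc2c(N)nc(Nc3ccccc3)nc21` — 23500 nM

The read-out is an ADME assay on Huh-7 cells (Homo sapiens) for cytotoxicity, read by MTT assay, with a stated time of 4 h, at 37 degrees C; on this read-out higher numbers stand for lower toxicity in this test and lower numbers for higher toxicity in this test. Compound 2 gives 13800 nM. One change on the core of compound 2, (2,6-difluorophenyl in place of phenyl on an aromatic carbon), gives compound 1; the step is a 5.8-fold lower number from compound 2 to compound 1 (0.76 log units; beyond the scatter). The other change on that core, (methyl in place of hydrogen on an aromatic nitrogen), gives compound 3; the step is a 1.7-fold higher number from compound 2 to compound 3 (0.23 log units; within the scatter), and compound 3 holds the highest number of the three measured, though its gap to compound 2 is within the scatter, so no order between these two is claimed.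

The unmeasured compound 4 `Cn1c(=O)c(-c2c(F)cccc2F)cc2c(N)nc(Nc3ccccc3)nc21` carries the same kind of change on the core of compound 3, (2,6-difluorophenyl in place of phenyl on an aromatic carbon). The two cores differ by the methyl in place of hydrogen on an aromatic nitrogen just described. Around the place of the change, the description for compound 4 adds that the position is meta to a methyl group (1 heavy atom), which is absent around the same place in compound 1; otherwise the two place descriptions agree.

Going by the values given here, only one measured instance of this change exists, so the expectation rests on it alone. Among the compounds with values here, compound 4 is expected to show a step of about a 5.9-fold lower number from compound 3 to compound 4 (0.77 log units; beyond the scatter), similar in size to the one measured step of this kind, because a 5.8-fold lower number from compound 2 to compound 1 (0.76 log units; beyond the scatter) is the only guide for this change. On that basis compound 4 is estimated at 4000 nM, with a plausible span from 1500 nM to 11000 nM.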

Compound 4, half-maximal cytotoxic concentration: 10400 nM
The estimate for compound 4 lay 2.6-fold (0.41 log units) below the measured number; low and high end bracket the measured number.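

In this assay, 2,6-difluorophenyl in place of phenyl also gives a lower number on the core of compound 3, with a 2.3-fold lower number from compound 3 to compound 4 (0.35 log units; beyond the scatter), so the direction seen on the core of compound 2 carries over in this one further pair, and the sizes of the two steps cannot be told apart: the same change on two cores in this assay, a 5.8-fold lower number (0.76 log units; beyond the scatter) from compound 2 to compound 1 and a 2.3-fold lower number (0.35 log units; beyond the scatter) from compound 3 to compound 4, 2.5-fold (0.41 log units) apart, within the scatter of two such steps. Methyl in place of hydrogen on the aromatic nitrogen gives a 4.3-fold higher number from compound 1 to compound 4 (0.64 log units; beyond the scatter), a step beyond the scatter, while the same change on the core of compound 2 stays within it, yet these two steps cannot be told apart either: the same change on two cores in this assay, a 1.7-fold higher number (0.23 log units; within the scatter) from compound 2 to compound 3 and a 4.3-fold higher number (0.64 log units; beyond the scatter) from compound 1 to compound 4, 2.5-fold (0.41 log units) apart, within the scatter of two such steps. These notes rest on a single set of four compounds, so they support rough additivity of the two changes within this set but show neither a general rule for the series nor why the steps take these sizes.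

Open, as far as these compounds go, is how a phenyl carrying one fluorine, a chlorine or a methoxy group would behave on either core, and whether an ethyl or a longer chain on the aromatic nitrogen would follow the methyl. Equally open, from the compounds shown here alone, is whether both changes would hold their direction on a core that also carries an amine or a carboxylic acid.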